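A few compounds are considered here, and "the series" means these few. Any claim that something is new, unique, unknown or untested is made for them only; others in the source may bear on it.

Working notes on the series. For the measured compounds named here, compound 2 `COc1ccc(CNC(=O)CN2C(=O)/C(=C/c3ccc(-c4ccc(Cl)cc4)o3)SC2=S)cc1` stands lowest of the two numbers so far in a functional assay on K562 cells (Homo sapiens) for cytotoxicity, read by MTT assay, with a stated time of 72 h (on this read-out lower numbers stand for stronger inhibition and higher numbers for weaker inhibition), where compound 2 gives 40000 nM; the nearest is compound 1 `O=C(CN1C(=O)/C(=C/c2ccc(-c3ccc(Cl)cc3)o2)SC1=S)NCc1ccc(F)cc1`, which in this assay gives 150000 nM, a gap read as a 3.8-fold lower number from compound 1 to compound 2 (0.57 log units; beyond the scatter). Going by the values given here, the step to compound 3 `Cc1ccc(CNC(=O)CN2C(=O)/C(=C/c3ccc(-c4ccc(Cl)cc4)o3)SC2=S)cc1` is methyl in place of methoxy on an aromatic carbon, at the same place on the benzyl ring that the one measured step touches. Among the compounds with values here, that step, a 3.8-fold lower number from compound 1 to compound 2 (0.57 log units; beyond the scatter), shows that the group on this aromatic carbon moves this assay by a modest amount, but a swap of methoxy for methyl is a different exchange and no directly matching step is in hand. A small move toward a higher number is therefore expected, of size a 1.6-fold higher number from compound 2 to compound 3 (0.21 log units; within the scatter), possibly no further than the scatter. For compound 3 in this assay the estimate is 65000 nM, with a range from 25000 nM to 170000 nM.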

Compound 3, half-maximal inhibitory concentration: 45000 nM
Estimate against measurement, compound 3: 1.4-fold (0.16 log units) above; measured number inside the range.
By their numbers in this assay, from the lowest: compounds 2 and 3 (each within the scatter of the next); then compound 1.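

At this aromatic carbon, para to a large group, the exchange of methoxy for methyl leaves this assay without a readable change, at a 1.1-fold higher number from compound 2 to compound 3 (0.05 log units; within the scatter), so the oxygen of methoxy and the hydrogen-bond acceptor counted with it are not needed to hold this level. Fluoro stands apart from both groups, now on two steps rather than one, as methyl also separates from it by a 3.3-fold lower number from compound 1 to compound 3 (0.52 log units; beyond the scatter), a size close to that of the earlier step from fluoro to methoxy. No measurement at hand gives a reason for this separation.

Going by these compounds, how a hydroxyl, an amine or a carboxylic acid on this carbon would read remains open. So does whether a longer chain such as ethoxy stays level with compound 2 and compound 3 or moves beyond the scatter.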